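Compound 4 in the thallium flux assay: an open question

A few compounds are considered here, and "the series" means these few. Any claim that something is new, unique, unknown or untested is made for them only; others in the source may bear on it.

The series shares one core, seen in compound 1 `Cc1c(OCCCCOc2cccc(C(=O)O)c2)ccc(C(=O)CC(C)C)c1C`, compound 2 `Cc1c(OCCCCOc2ccc(C(=O)O)c(Cl)c2)ccc(C(=O)CC(C)C)c1C` and compound 3 `Cc1c(OCCCCOc2ccc(C(=O)O)c(Cl)c2)ccc(C(=O)CC(C)C)c1O`. In an assay on HEK293 cells for positive allosteric modulation of metabotropic glutamate receptor 3 (Rattus norvegicus), read by thallium flux, with a stated time of 2.5 min (a higher number here means that more compound is needed for the effect, a lower number that less compound is needed), compound 1 is recorded as "not determined" (no result reported), and compound 2 is likewise recorded as "not determined" (no result reported). Only compound 3 carries a number: in this assay compound 3 gives 2050 nM. Compound 2 therefore stands without a value of its own; the one measured relative, compound 3, differs from it in a second place as well, so its value is a loose anchor and no more.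

The new compound 4 `Cc1c(OCCCCOc2ccc(C(=O)O)c(Cl)c2)ccc(C(=O)CC2CCCC2)c1C` differs from compound 2 by one change:
cyclopentyl in place of isopropyl on a saturated chain carbon bound to a carbonyl carbon

Going by the values given here, no pair of measured compounds shows what this change does, and no step is available to size it. In this assay, among the compounds with values here, the expectation for compound 4 must therefore rest on the only measured neighbour, compound 3, and on the absence of any guide to direction; a step within the scatter, in either direction, is as plausible as one beyond it.

Taking compound 3 as the nearest reference, compound 4 is expected to give about 1500 nM in this assay, with a wide range from 300 nM to 8000 nM reflecting the missing anchor.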

Compound 4, half-maximal effective concentration: > 10000 nM
Compound 4: no number, only a limit (the forecaster's own chance of this, stated with the estimate: 30%); middle value at least 6.6-fold (0.82 log units) away from the limit.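

Going by these compounds alone, compound 2 has no single number in this assay, and no step to compound 4 can be read. Compound 4 gives > 10000 nM, which is a limit and not a number. The compounds shown leave open how far, and in which direction, cyclopentyl in place of isopropyl shifts the half-maximal effective concentration.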